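Ethynyl for iodo on the carboxamide: working notes

The source may report more compounds than this note shows. Statements on the series, on what has been measured and on what is new or still open speak of the compounds shown alone.

- compound 1 `NC(=O)c1nn([C@@H]2O[C@H](CO)[C@@H](O)[C@H]2O)cc1I` gives > 300000 nM as a limit
- compound 2 `COC(=O)c1nn([C@@H]2O[C@H](CO)[C@@H](O)[C@H]2O)cc1I` gives 2800 nM as a number

In a functional assay on HT-29 cells (Homo sapiens) (on this read-out lower numbers stand for stronger inhibition and higher numbers for weaker inhibition), compound 1 gives > 300000 nM and this is a limit, not a number.

Compound 3 `C#Cc1cn([C@@H]2O[C@H](CO)[C@@H](O)[C@H]2O)nc1C(N)=O` keeps the carbamoyl group of compound 1 and carries ethynyl in place of iodo on an aromatic carbon with the rest of the core unchanged. Among the measured compounds shown here, the one measured step is an at least 100-fold lower number from compound 1 to compound 2 (2.02 log units; beyond the scatter) and it is large, but it lies on the carbonyl carbon and not at the iodo place. It therefore gives no direct size for this change. With compound 1 at a limit, only a move toward lower numbers could be seen, and a modest one is expected, with a real chance of none.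

The estimated step is an at least 5.0-fold lower number from compound 1 to compound 3 (0.69 log units; beyond the scatter) in this assay and it stays uncertain.

Compound 3 is expected near 60000 nM with an estimated range from 3000 nM to 300000 nM in this assay as the working figure.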

Compound 3, half-maximal inhibitory concentration: > 300000 nM
Compound 3 gave a limit, no number; the forecaster's own chance of this, stated with the estimate: 40%; middle value at least 5.0-fold (0.69 log units) from the limit.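

Compound 1 and compound 3 cannot be compared, so no step can be read between them: both sit at the same limit of the assay: the limit of > 300000 nM in this assay, at which 2 of the 3 values shown sit.

The compounds shown leave open whether ethynyl in place of iodo on an aromatic carbon changes inhibition at all in this assay.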